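Acetyl to Ethyl on the Side Chain of Compound 1

A few compounds are considered here, and "the series" means these few. Any claim that something is new, unique, unknown or untested is made for them only; others in the source may bear on it.

Compound 1, `CC(=O)C(C)CCCCc1cc(O)c(C)c(=O)o1`, was tested in a functional assay on HepG2 cells (Homo sapiens) for cytotoxicity, read by MTT assay; on this read-out higher numbers stand for weaker inhibition and lower numbers for stronger inhibition. In this assay compound 1 gives > 200000 nM, which is a limit of the assay rather than a measured number. Among the compounds with values here, compound 2, `Cc1c(O)cc(CCCCC(C)(C)O)oc1=O`, is the only other compound measured. In this assay compound 2 gives > 200000 nM, again a limit. The step that the two limits leave unreadable from compound 1 to compound 2 cannot be read in size since (the limit of > 200000 nM in this assay, at which 2 of the 2 values shown sit). Compound 3, `CCC(C)CCCCc1cc(O)c(C)c(=O)o1`, carries a different change: ethyl in place of acetyl on a saturated chain carbon bound to two saturated chain carbons. Within the data shown here, no measured step covers this exchange, and the one step that is known tells nothing about size. Among the measured compounds shown here, with both known values sitting at the limit and no step to lean on, compound 3 is expected to show the step of a number no higher from compound 1 to compound 3 (the limit leaves the size open), landing at the same limit. For compound 3 the estimate is 200000 nM, with a range from 100000 nM to 400000 nM.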

Compound 3, half-maximal inhibitory concentration: > 200000 nM
Compound 3 ended at the assay's limit; the forecaster's own chance of this, stated with the estimate: 85%; the middle value lies on the limit itself.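

The steps among compound 1, compound 2 and compound 3 cannot be read in size, as each result is a limit and not a number: the limit of > 200000 nM in this assay, at which 3 of the 3 values shown sit.

The compounds shown leave open whether 1-acetylethyl, 1-hydroxy-1-methylethyl and sec-butyl differ at all in this assay.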